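A few compounds are considered here, and "the series" means these few. Any claim that something is new, unique, unknown or untested is made for them only; others in the source may bear on it.

Three compounds share one core and differ only in the ring carried on the double bond. Compound 1 `COc1ccc(CNC(=O)/C(C#N)=C/c2ccoc2)cc1` gives 5000 nM in a functional assay on A-431 cells (Homo sapiens) for inhibition, read by MTT assay, with a stated time of 72 h; a higher number here means a weaker inhibitor of growth, a lower number a stronger inhibitor of growth. Compound 2 `COc1ccc(CNC(=O)/C(C#N)=C/c2ccc(C)cc2)cc1` gives 26000 nM, and a 5.2-fold higher number from compound 1 to compound 2 (0.72 log units; beyond the scatter). Compound 3 `COc1ccc(CNC(=O)/C(C#N)=C/c2ccc3ccccc3c2)cc1` gives 37000 nM, the highest of the three numbers; its gap to compound 2 lies within the scatter, its gap to compound 1 beyond it. Compound 4 `N#C/C(=C\c1ccc2ccccc2c1)C(=O)NCc1ccc(Cl)c(Cl)c1` differs from compound 3 at a different place: 3,4-dichlorophenyl in place of 4-methoxyphenyl on a saturated chain carbon bound to an amide-type nitrogen. Among the measured compounds shown here, none of the measured steps touches this part of the molecule, so the three values carry no direct information on it, and no step beyond the scatter is expected in this assay. Compound 4 is therefore expected to give 30000 nM, between 8000 nM and 100000 nM. The expected step is a 1.2-fold lower number from compound 3 to compound 4 (0.09 log units; within the scatter).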

Compound 4, concentration for 50% growth inhibition: 50000 nM
For compound 4 the middle estimate is 1.7-fold (0.22 log units) below the measured one; measured number inside the range.
By their numbers in this assay, from the lowest: compound 1; then compounds 2, 3 and 4 (each within the scatter of the next).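

In this assay, among the compounds shown here, putting 3,4-dichlorophenyl in place of 4-methoxyphenyl on a saturated chain carbon bound to an amide-type nitrogen gives a 1.4-fold higher number from compound 3 to compound 4 (0.13 log units; within the scatter), the first reading at this position. With the ring of compound 3 on the double bond, the two groups cannot be told apart here. No supporting measurement bears on this result. On these data alone, it remains open whether the same exchange would read alike on compound 1, which gives 5000 nM. A carboxylic acid or an amine at this position is also an open case.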